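Glucagon receptor antagonists: pyrazolyl-aryl ether series, working notes

This account rests on a few compounds, and the source may have more. Where it says the series, first, only, none or still open, it means among the compounds named here.

Measured so far:
compound 1 `CCCC(Nc1ccc(-n2cc(C(F)(F)F)cn2)nc1)c1ccc(C(=O)NCCC(=O)O)cc1` 1300 nM
compound 2 `CCCC(Oc1ccc(-n2cc(C(F)(F)F)c(C)n2)cc1)c1ccc(C(=O)NCCC(=O)O)cc1` 8300 nM
compound 3 `CCC(Oc1ccc(-n2cc(C(F)(F)F)cn2)cc1)c1ccc(C(=O)NCCC(=O)O)cc1` > 22000 nM

In a functional assay on cells for antagonist activity at Glucagon receptor (Homo sapiens), read by cAMP accumulation, in the presence of a further agent that is not named here (on this read-out lower numbers stand for stronger inhibition and higher numbers for weaker inhibition), compound 2 gives the highest of the two numbers; compound 1 sits at a lower number in this assay, and the gap between them is beyond the scatter. For compound 3 this assay reports only a limit, (the limit of > 22000 nM in this assay, at which 1 of the 3 values shown sits), not a number.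

Compound 4 `CCCC(Oc1ccc(-n2cc(Cl)cn2)cc1)c1ccc(C(=O)NCCC(=O)O)cc1` differs from compound 2 in one place: 4-chloro-1H-pyrazol-1-yl in place of 3-methyl-4-(trifluoromethyl)-1H-pyrazol-1-yl on an aromatic carbon. Within the data shown here, no measured pair bears on this change. The expectation is a modest shift to a weaker number in this assay, of a size near the edge of the scatter, a 1.7-fold higher number from compound 2 to compound 4 (0.23 log units; within the scatter). Compound 4 is estimated at 14000 nM, between 4000 nM and 40000 nM, with a fair chance that only a limit is returned.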

Compound 4, antagonist equilibrium constant: 6500 nM
Estimate against measurement, compound 4: 2.2-fold (0.33 log units) above; low and high end bracket the measured number.
By their numbers in this assay, from the lowest: compound 1; then compounds 4 and 2 (each within the scatter of the next). At a limit, above all of these: compound 3.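

In this assay, 4-chloro-1H-pyrazol-1-yl in place of 3-methyl-4-(trifluoromethyl)-1H-pyrazol-1-yl gives a 1.3-fold lower number from compound 2 to compound 4 (0.11 log units; within the scatter). At this aromatic carbon, para to a large group, the two groups cannot be told apart, so within this pair neither the trifluoromethyl nor the methyl is needed to hold the number. Among these compounds, nothing measured so far gives a cause for this result. Still open, from the compounds shown here alone, is whether a nitrile in place of the chlorine would move the number beyond the scatter. Compound 1 differs from compound 2 in more than one place, so its lower number cannot be assigned to any single change.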